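Extending the carbamoyl end of compound 2

The compounds below may be only part of what the source reports. "The series", "measured", "known", "first", "only" and "open" are said of these compounds alone.

Compound 1: `NC(=O)N1CCN(C(=S)SCc2cn(Cc3ccccc3F)nn2)CC1`, > 128000 nM
Compound 2: `Cc1ccc(Cn2cc(CSC(=S)N3CCN(C(N)=O)CC3)nn2)cc1`, > 128000 nM

In a functional assay on SMMC-7721 cells (Homo sapiens) for cytotoxicity, read by MTT assay, with a stated time of 72 h (on this read-out lower numbers stand for stronger inhibition and higher numbers for weaker inhibition), compound 1 reaches only a limit of the assay, > 128000 nM. Compound 2 likewise gives only a limit in this assay, > 128000 nM. Within the data shown here, the one measured step, a step that the two limits leave unreadable from compound 1 to compound 2, cannot be sized, since both ends sit at the limit; this is summarised by the limit of > 128000 nM in this assay, at which 2 of the 2 values shown sit. Compound 2 therefore stands nowhere on a numerical scale, only at the upper boundary of what this assay reports.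

Compound 3, `CCN(C)C(=O)N1CCN(C(=S)SCc2cn(Cc3ccc(C)cc3)nn2)CC1`, differs from compound 2 by ethyl(methyl)amino in place of amino on a carbonyl carbon, the carbamoyl becoming an ethyl(methyl)carbamoyl. Among the measured compounds shown here, no measured step touches this carbonyl end of the molecule, and the only step known, from the fluorinated to the methylated aryl ring, was itself unreadable. Nothing in the two results suggests that a change at the carbamoyl end would move the compound off the limit, so compound 3 is expected to remain near it, with an estimated step that the limit leaves unreadable from compound 2 to compound 3. The estimate for compound 3 is 150000 nM, expected to lie between 50000 nM and 500000 nM, most likely again reported only as a limit.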

Compound 3, half-maximal inhibitory concentration: > 128000 nM
Compound 3: no number, only a limit; the forecaster's own chance of this, stated with the estimate: 80%; the middle value lies beyond the limit too.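

In this assay compound 3 gives > 128000 nM, which is a limit and not a number. No size can therefore be read for the step between compound 2 and compound 3. All three compounds share one result: the limit of > 128000 nM in this assay, at which 3 of the 3 values shown sit. They leave open whether any change among them alters cytotoxicity, and what structure would give a measurable value.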